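A few compounds are considered here, and "the series" means these few. Any claim that something is new, unique, unknown or untested is made for them only; others in the source may bear on it.

The shared core appears first in compound 1 `NS(=O)(=O)c1cccc(/N=C2\NC(=O)/C(=C3/C(=O)Nc4ccccc43)S2)c1`, which in a functional assay on Caco-2 cells (Homo sapiens) for antiproliferative activity, read by MTT assay (on this read-out higher numbers stand for weaker inhibition and lower numbers for stronger inhibition), gives 12100 nM. Compound 2 `NS(=O)(=O)c1cccc(/N=C2\NC(=O)/C(=C3/C(=O)Nc4ccc(Br)cc43)S2)c1` carries bromo in place of hydrogen on an aromatic carbon and gives 10800 nM in this assay; the step of a 1.1-fold lower number from compound 1 to compound 2 (0.05 log units; within the scatter) stays within the scatter. Compound 3 `NS(=O)(=O)c1ccc(/N=C2\NC(=O)/C(=C3/C(=O)Nc4ccc([N+](=O)[O-])cc43)S2)cc1` carries a nitro group and a 4-sulfamoylphenyl on the double-bonded nitrogen and gives 13800 nM in this assay. Among the three numbers that of compound 3 is the highest, though its separations from compound 1 and from compound 2 both lie within the scatter, so the three compounds cannot be told apart in this assay.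

Compound 4 `NS(=O)(=O)c1cccc(/N=C2\NC(=O)/C(=C3/C(=O)Nc4ccc([N+](=O)[O-])cc43)S2)c1` has not yet been measured in this assay. It differs from compound 3 at the double-bonded nitrogen: 3-sulfamoylphenyl in place of 4-sulfamoylphenyl on a double-bonded nitrogen. Among the compounds with values here, no measured pair isolates this exchange of sulfamoylphenyl groups. Within the data shown here, the only measured step concerns the other ring and lay within the scatter, and compounds 1 and 2, which carry the 3-sulfamoylphenyl, gave numbers that do not separate from that of compound 3. The step of a 1.2-fold lower number from compound 3 to compound 4 (0.06 log units; within the scatter) is therefore expected to remain within the scatter. Compound 4 is estimated at 12000 nM, with a range from 6000 nM to 24000 nM.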

Compound 4, half-maximal inhibitory concentration: 20600 nM
Compound 4: the middle estimate sits 1.7-fold (0.23 log units) below what was measured; measured number inside the range.
By their numbers in this assay, from the lowest: compounds 2, 1, 3 and 4 (each within the scatter of the next).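

The exchange of 4-sulfamoylphenyl for 3-sulfamoylphenyl on a double-bonded nitrogen now has a measured pair: in this assay the change gives a 1.5-fold higher number from compound 3 to compound 4 (0.17 log units; within the scatter), so with nitro on the other ring the two placements of the sulfamoyl group cannot be told apart. With the 3-sulfamoylphenyl held constant, nitro can now be set against the two other groups on that aromatic carbon, giving a 1.7-fold higher number from compound 1 to compound 4 (0.23 log units; within the scatter) for nitro in place of hydrogen and a 1.9-fold higher number from compound 2 to compound 4 (0.28 log units; within the scatter) for nitro in place of bromo, so neither exchange resolves the compounds. Nothing available explains why these changes leave the numbers unresolved.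

The one pair shown for the sulfamoylphenyl exchange carries nitro, so it remains open whether the same exchange would also stay within the scatter with hydrogen or bromo on the other ring. On these data alone, it also remains open whether an amine or a carboxylic acid on that aromatic carbon, or a carboxylic acid in place of the sulfamoyl group, would move the number beyond the scatter in this assay.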